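This account rests on a few compounds, and the source may have more. Where it says the series, first, only, none or still open, it means among the compounds named here.

Measured so far in a functional assay on A549 cells (Homo sapiens) for antiproliferative activity, read by MTT assay, with a stated time of 24 h; a lower number here means a stronger inhibitor, a higher number a weaker inhibitor:
compound 1, `Cc1cccc(-n2cc(-c3cccc(NS(=O)(=O)c4c[nH]c(=O)[nH]c4=O)c3)nn2)c1`, 3550 nM;
compound 2, `O=c1[nH]cc(S(=O)(=O)Nc2ccc(-c3cn(-c4ccccc4)nn3)cc2)c(=O)[nH]1`, 7170 nM;
compound 3, `O=c1[nH]cc(S(=O)(=O)Nc2ccc(-c3cn(-c4ccccc4F)nn3)cc2)c(=O)[nH]1`, 5960 nM.

All three numbers sit inside the usual scatter of one another; compound 3 therefore stands apart from neither compound 2 nor compound 1 in this assay. Going by the values given here, the single one-place step available, a 1.2-fold lower number from compound 2 to compound 3 (0.08 log units; within the scatter), was itself within the scatter.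

Compound 4 is `O=c1[nH]cc(S(=O)(=O)Nc2ccc(-c3cn(-c4cccc(Cl)c4)nn3)cc2)c(=O)[nH]1`. Its change from compound 3 is 3-chlorophenyl in place of 2-fluorophenyl on an aromatic nitrogen. Among the compounds with values here, no measured step swaps one substituted phenyl for another on this ring nitrogen, so the only guide is that the one aryl-ring edit seen, from compound 2 to compound 3, moved nothing beyond the scatter. No step beyond the scatter is expected here either: compound 4 is estimated at 5000 nM in this assay, between 2500 nM and 10000 nM, an expected step of a 1.2-fold lower number from compound 3 to compound 4 (0.08 log units; within the scatter).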

Compound 4, half-maximal inhibitory concentration: 2310 nM
For compound 4 the middle estimate is 2.2-fold (0.34 log units) above the measured one, and the stated range ends above it.
By their numbers in this assay, from the lowest: compounds 4, 1, 3 and 2 (each within the scatter of the next, the first and the last beyond it).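

In this assay the aryl group on the aromatic nitrogen now shows a step beyond the scatter, with a 3.1-fold lower number from compound 2 to compound 4 (0.49 log units; beyond the scatter) for the chloro edit and a 2.6-fold lower number from compound 3 to compound 4 (0.41 log units; beyond the scatter) for the exchange of 2-fluorophenyl for 3-chlorophenyl. The fluoro edit alone gave only a 1.2-fold lower number from compound 2 to compound 3 (0.08 log units; within the scatter) within the scatter, so this position is not indifferent to its aryl substituent. Nothing available explains the change.

Still open, on these data alone, is whether the chlorine itself or its place on the phenyl carries the step. Also open, as far as these compounds go, is how a methoxy group or a carboxylic acid would behave on this ring.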